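The source may report more compounds than this note shows. Statements on the series, on what has been measured and on what is new or still open speak of the compounds shown alone.

The measured compounds are these.
Compound 1 `COc1ccc(-c2cc(Nc3nnc(-c4ccc(C)cc4)s3)cs2)cc1`: in a functional assay on SK-MEL-28 cells (Homo sapiens) for inhibition, read by colorimetric assay and MTT assay, with a stated time of 72 h (on this read-out higher numbers stand for weaker inhibition and lower numbers for stronger inhibition), compound 1 gives > 100000 nM, which is a limit of the assay.
Compound 2 `Cc1ccc(-c2nnc(Nc3csc(-c4ccccc4)c3)s2)cc1`: in this assay compound 2 gives > 100000 nM, again only a limit.
Compound 3 `Cc1ccc(-c2cc(Nc3nnc(-c4ccc(C)cc4)s3)cs2)cc1`: in this assay compound 3 gives > 100000 nM, also a limit.

Compound 2 thus stands only at a limit, and the two further values shown are limits as well, all sitting at the limit of > 100000 nM in this assay, at which 3 of the 3 values shown sit. Compound 4 `COc1ccc(-c2nnc(Nc3csc(-c4ccccc4)c3)s2)cc1` differs from compound 2 in one place: methoxy in place of methyl on an aromatic carbon. The measured steps that involve this part of the structure are a step that the two limits leave unreadable from compound 2 to compound 3, a step that the two limits leave unreadable from compound 1 to compound 2 and a step that the two limits leave unreadable from compound 1 to compound 3, none of them readable in size. Among the measured compounds shown here, no readable step therefore bears on the change, and nothing among the measured compounds points away from the limit. Compound 4 is expected to remain at that limit, which amounts to an estimated step that the limit leaves unreadable from compound 2 to compound 4. The estimate for compound 4 is 150000 nM, with a range from 50000 nM to 500000 nM.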

Compound 4, half-maximal inhibitory concentration: > 100000 nM
Compound 4 was reported as a limit (the forecaster's own chance of this, stated with the estimate: 90%); the middle value lies beyond the limit too.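

Among the compounds shown here, compound 2 and compound 4 both stand only at a limit, so no step between them can be read. The compounds shown leave open how strongly any of them inhibits and whether any change to the shared core would give a measurable value.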